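Replacing the pyridine on the benzyl ether: expected toxicity shift

This account rests on a few compounds, and the source may have more. Where it says the series, first, only, none or still open, it means among the compounds named here.

Measured compounds:
- compound 1 `N#Cc1ccc(Nc2nccc(OCc3cccnc3)n2)cc1`: 6400 nM
- compound 2 `N#Cc1ccc(Nc2nccc(OCc3ccccc3F)n2)cc1`: 151000 nM
- compound 3 `Cc1cccc(COc2ccnc(Nc3ccc(C#N)cc3)n2)c1`: 30000 nM

In an ADME assay on MT4 cells (Homo sapiens) for cytotoxicity, read by MTT assay, with a stated time of 5 days (on this read-out higher numbers stand for lower toxicity in this test and lower numbers for higher toxicity in this test), compound 1 gives the lowest number of the three, so it is the most toxic here. Compound 4 `N#Cc1ccc(Nc2nccc(OCc3cc(F)ccc3Br)n2)cc1` differs from it by 2-bromo-5-fluorophenyl in place of pyridin-3-yl on a saturated chain carbon bound to an oxygen on an aromatic ring. For the measured compounds named here, two measured steps bear on this, both swapping the pyridin-3-yl for a carbon-only ring: a 24-fold higher number from compound 1 to compound 2 (1.37 log units; beyond the scatter) and a 4.7-fold higher number from compound 1 to compound 3 (0.67 log units; beyond the scatter). Both raised the number beyond the scatter, one strongly, one modestly. A higher number, meaning lower toxicity, is therefore expected for compound 4, with a step of roughly a 9.4-fold higher number from compound 1 to compound 4 (0.97 log units; beyond the scatter). Compound 4 is estimated at 60000 nM, in the range 15000 nM to 200000 nM.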

Compound 4, half-maximal cytotoxic concentration: 190000 nM
Estimate against measurement, compound 4: 3.2-fold (0.50 log units) below; low and high end bracket the measured number.
By their numbers in this assay, from the lowest: compound 1; then compound 3; then compounds 2 and 4 (each within the scatter of the next).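

In this assay a third carbon-only ring in place of pyridin-3-yl gives a 30-fold higher number from compound 1 to compound 4 (1.47 log units; beyond the scatter) and so the rise holds for all three such swaps shown. The carbon-only rings are not all alike: 2-bromo-5-fluorophenyl in place of 3-methylphenyl gives a 6.3-fold higher number from compound 3 to compound 4 (0.80 log units; beyond the scatter) while in place of 2-fluorophenyl it gives a 1.3-fold higher number from compound 2 to compound 4 (0.10 log units; within the scatter) and so adds no clear change. No measurement shown gives a reason for these differences. A plain phenyl ring at this place would show what the loss of the ring nitrogen does alone, and an amine or a carboxylic acid on the ring remains an open case.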